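This account rests on a few compounds, and the source may have more. Where it says the series, first, only, none or still open, it means among the compounds named here.

Of the compounds shown here, two from this set have been measured in an assay on isolated protein for inhibition of phosphatidylinositol 4,5-bisphosphate 3-kinase catalytic subunit beta isoform (Homo sapiens), read by 33P incorporation, with a stated time of 60 min; on this read-out higher numbers stand for weaker inhibition and lower numbers for stronger inhibition. Compound 1 `Cc1ccc([N+](=O)[O-])cc1S(=O)(=O)N(C)/N=C/c1cnn2ccc(Cl)cc12` gives 390 nM. Compound 2 `COC(=O)c1ccn2ncc(/C=N/N(C)S(=O)(=O)c3cc([N+](=O)[O-])ccc3C)c2c1` gives > 1000 nM, and this is a limit of the assay rather than a number. Among the measured compounds shown here, the one measured step, an at least 2.5-fold higher number from compound 1 to compound 2 (0.40 log units; beyond the scatter), is the replacement of chloro by methoxycarbonyl, and it ends at the limit of > 1000 nM in this assay, at which 1 of the 2 values shown sits. So compound 2 stands at the weak end of what has been seen, with only a bound known for it.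

Compound 3 `Cc1ccc([N+](=O)[O-])cc1S(=O)(=O)N(C)/N=C/c1cnn2ccc(C(=O)N(C)C)cc12` keeps the shared core and differs from compound 2 in one place: dimethylamino in place of methoxy on a carbonyl carbon. For the measured compounds named here, no measured step touches this part of the molecule; the step from compound 1 to compound 2 changed the group sitting on the core, not what hangs from the carbonyl carbon. The expected step in this assay is therefore one of no clear size or direction, namely a step that the limit leaves unreadable from compound 2 to compound 3. Compound 2 stands at the limit > 1000 nM. The estimate for compound 3 is accordingly 2000 nM, with an expected range from 700 nM to 6000 nM, and a fair chance that only a limit is reported again.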

Compound 3, half-maximal inhibitory concentration: > 1000 nM
Compound 3 was reported as a limit (the forecaster's own chance of this, stated with the estimate: 60%); the middle value does not contradict the limit.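

Swapping the methoxy of the ester for dimethylamino, which turns methoxycarbonyl into dimethylcarbamoyl, does not bring this position back into the readable range of this assay. Set against the chloro compound, the new group gives an at least 2.5-fold higher number from compound 1 to compound 3 (0.40 log units; beyond the scatter), so both carbonyl-linked groups tested on this aromatic carbon now read as weaker than chloro, and no compound shown goes against this. Compound 2 and compound 3 both stand as limits, so the step between them cannot be read and the ester and the amide cannot be ranked; what the result adds is that the loss seen with the ester also appears with a second carbonyl group, and the values now pile up at one end of the scale: the limit of > 1000 nM in this assay, at which 2 of the 3 values shown sit.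

The compounds shown leave open how much weaker than the limit either carbonyl compound really is, and so whether the ester or the amide is the better of the two. They also leave open how a carboxylic acid, a primary amine or a plain methyl on the same aromatic carbon would compare with chloro in this assay.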